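Swapping methyl for chloro on a fused ring

The compounds below may be only part of what the source reports. "The series", "measured", "known", "first", "only" and "open" are said of these compounds alone.

Three close relatives share one core. Compound 1 `Cc1ccc2nc(Nc3nc(Nc4ccc(S(N)(=O)=O)cc4)ncc3F)sc2c1` gives 1460 nM in a functional assay on HCT-116 cells (Homo sapiens) for antiproliferative activity, read by MTT assay, with a stated time of 48 h; on this read-out higher numbers stand for weaker inhibition and lower numbers for stronger inhibition. Compound 2 `Cc1ccc2nc(Nc3nc(Nc4ccc(S(N)(=O)=O)cc4)ncc3C)sc2c1` gives 3870 nM, and compound 3 `NS(=O)(=O)c1ccc(Nc2ncc(F)c(Nc3nc4ccccc4s3)n2)cc1` gives 3260 nM. Compound 2 has the highest number of the three, meaning the weakest inhibition; its value and that of compound 3 are within the scatter of each other, so no order between them can be read, while the step of a 2.7-fold higher number from compound 1 to compound 2 (0.42 log units; beyond the scatter) lies beyond the scatter.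

Compound 4 `Cc1cnc(Nc2ccc(S(N)(=O)=O)cc2)nc1Nc1nc2ccc(Cl)cc2s1` has not yet been measured. It differs from compound 2 by chloro in place of methyl on an aromatic carbon. Of the measured steps, a 2.2-fold higher number from compound 1 to compound 3 (0.35 log units; beyond the scatter) touches the same methyl, removing it to leave hydrogen, and gave only a modest weakening. The other step, a 2.7-fold higher number from compound 1 to compound 2 (0.42 log units; beyond the scatter), concerns a different ring and bears less directly. Going by the values given here, no measured compound carries chloro here, so the effect of putting chloro in that place is unknown, and a small step is the most plausible guess.

Compound 4 is therefore expected to give about 3500 nM, with a range from 1500 nM to 8000 nM. For compound 4 this amounts to an expected 1.1-fold lower number from compound 2 to compound 4 (0.04 log units; within the scatter), likely within the scatter.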

Compound 4, half-maximal inhibitory concentration: 2520 nM
Compound 4: middle estimate off by 1.4-fold (0.14 log units), on the high side; the measured number falls inside the stated range.
By their numbers in this assay, from the lowest: compounds 1, 4, 3 and 2 (each within the scatter of the next, the first and the last beyond it).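

The swap of methyl for chloro gives a 1.5-fold lower number from compound 2 to compound 4 (0.19 log units; within the scatter) in this assay, so chloro and methyl cannot be told apart at this place on the six-membered carbon ring. Going by these compounds alone, until now the only change read here was the removal of methyl to leave hydrogen, a 2.2-fold higher number from compound 1 to compound 3 (0.35 log units; beyond the scatter) with fluoro on the other ring, so this is the first sign that a group other than methyl can sit here without a change beyond the usual scatter, although this swap was read with methyl rather than fluoro on the other ring. Nothing given here explains why the two groups give numbers this close.

Within the data shown here, whether chloro would behave the same way with fluoro on the other ring remains open, since the two steps at this place were read against different partners, and compound 1, which has the lowest number of the set, has no chloro counterpart. It is also unknown how a larger or very different group would fare here, such as methoxy, trifluoromethyl, an amine or a carboxylic acid.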